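Relocating the methoxy on the anilide of compound 2

The source may hold more compounds than are shown below. What is called first, only, known or untested is meant among the compounds shown, and "the series" means these compounds.

Working notes on the anilide series. For the measured compounds named here, compound 2 `COc1ccccc1NC(=O)CSc1nnc(-c2ccoc2C)n1Cc1ccco1` is the weaker of the two measured compounds: in a functional assay on CHO cells for antagonist activity at Orexin receptor type 2 (Homo sapiens), read by FLIPR and calcium flux (a lower number here means a stronger inhibitor, a higher number a weaker inhibitor), compound 2 gives 501 nM, the highest of the two numbers so far. Going by the values given here, compound 1 `Cc1ccc(NC(=O)CSc2nnc(-c3ccoc3C)n2Cc2ccco2)cc1` gives 39.8 nM in this assay, and the step of a 13-fold higher number from compound 1 to compound 2 (1.10 log units; beyond the scatter) is the only measured step in the set. Compound 3 `COc1ccc(NC(=O)CSc2nnc(-c3ccoc3C)n2Cc2ccco2)cc1` is not yet measured. The change from compound 2 to compound 3 is 4-methoxyphenyl in place of 2-methoxyphenyl on an amide-type nitrogen. Among the compounds with values here, the single measured step bears on this only in part: it changes both the nature of the substituent, methyl to methoxy, and its place on the phenyl ring, so the two contributions cannot be separated. It shows only that the 4-methylphenyl anilide is the stronger of the two. Compound 3, a 4-methoxyphenyl anilide, shares the arrangement of compound 1, so a partial recovery is expected, a step of a 4.2-fold lower number from compound 2 to compound 3 (0.62 log units; beyond the scatter), but not a full return to the number of compound 1. The estimate for compound 3 is 120 nM, with a range from 40 nM to 400 nM.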

Compound 3, inhibition constant: 200 nM
Estimate against measurement, compound 3: 1.7-fold (0.22 log units) below; measured number inside the range.
By their numbers in this assay, from the lowest: compound 1; then compound 3; then compound 2.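

In this assay, with methoxy held constant, the change of place alone gives a 2.5-fold lower number from compound 2 to compound 3 (0.40 log units; beyond the scatter), so the place on the phenyl ring counts in its own right, which the earlier step could not show. With the place held constant, methoxy in place of methyl on an aromatic carbon gives a 5.0-fold higher number from compound 1 to compound 3 (0.70 log units; beyond the scatter), so the choice of substituent also counts, and both contributions lie beyond the scatter. No measurement shown accounts for either step.

The series does not show whether the two contributions would combine in the same way on another substituent, as the anilide with methyl in the place the methoxy holds in compound 2 would be needed to test that. It also leaves open how the 4-substituted anilide responds to a group other than methyl or methoxy, such as a chlorine, a trifluoromethyl, a longer chain, an amine or a carboxylic acid, and whether any of these would match or pass the 4-methylphenyl anilide of compound 1.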